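Buffer Stability of Compound 4, Estimated From Compounds 1 to 3

This account rests on a few compounds, and the source may have more. Where it says the series, first, only, none or still open, it means among the compounds named here.

Compound 1, `CCCCCc1ccc(-c2cc3cn([C@H]4C[C@H](O)[C@@H](COC(=O)[C@@H](NC(=O)[C@@H]5CCCN5C(=O)[C@@H](N)C(C)C)C(C)C)O4)c(=O)nc3o2)cc1`: in a physicochemical assay, read by HPLC, in phosphate buffer, with a stated time of 24 h, at pH 7.4 (on this read-out higher numbers stand for a more stable compound and lower numbers for a less stable compound), compound 1 gives > 95%, which is a limit of the assay and not a number.
Compound 2, `CCCCCc1ccc(-c2cc3cn([C@H]4C[C@H](OC(=O)[C@@H](NC(=O)[C@@H]5CCCN5C(=O)[C@@H](N)C(C)C)C(C)C)[C@@H](COC(=O)[C@@H](NC(=O)[C@@H]5CCCN5C(=O)[C@@H](N)C(C)C)C(C)C)O4)c(=O)nc3o2)cc1`: compound 2 gives > 95%, again a limit of the assay.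
Compound 3, `CCCCCc1ccc(-c2cc3cn([C@H]4C[C@H](O)[C@@H](COC(=O)[C@H](CC(C)C)NC(=O)[C@@H]5CCCN5C(=O)[C@@H](N)C(C)C)O4)c(=O)nc3o2)cc1`: compound 3 gives 69%.

Compound 1 thus stands at the limit of this assay, the same limit at which compound 2 sits (the limit of > 95% in this assay, at which 2 of the 3 values shown sit), and only compound 3 delivers a number. Going by the values given here, the one measured step is a number at least 26 percentage points lower from compound 1 to compound 3 (beyond the scatter), a change on the part that carries the ester.

Compound 4, `CCCCCc1ccc(-c2cc3cn([C@H]4C[C@H](O)[C@@H](COC(=O)[C@@H](NC(=O)[C@@H]5CCCN5C(=O)[C@@H](N)CCCCN)C(C)C)O4)c(=O)nc3o2)cc1`, differs from compound 1 elsewhere: 4-aminobutyl in place of isopropyl on a saturated chain carbon bound to an amine nitrogen and a carbonyl carbon. This is the terminal part, not the one bearing the ester, so the step from compound 1 to compound 3 bears on it only loosely, as a sign that changes in the peptide portion can cost stability. Compound 4 is expected to stay near the limit or a little under it, with a number at least 7 percentage points lower from compound 1 to compound 4 (that floor lies within the scatter) as the estimated step, because the ester-bearing part of compound 1 that gave > 95% is kept unchanged. The estimate for compound 4 is therefore 88%, ranging from 68% to 97%.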

Compound 4, percent of the compound remaining: > 95%
Compound 4: only a limit was reported; the forecaster's own chance of this, stated with the estimate: 40%; at least 7 percentage points between middle value and limit.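

In this assay compound 4 gives > 95%, a limit of the assay and not a number. Compound 1 also sits at a limit, so no step between compound 1 and compound 4 can be read: the limit of > 95% in this assay, at which 3 of the 4 values shown sit.

The compounds shown leave open whether 4-aminobutyl in place of isopropyl changes the result in this assay at all.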